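Methoxy for hydrogen on the anilide of compound 3

The source may hold more compounds than are shown below. What is called first, only, known or untested is meant among the compounds shown, and "the series" means these compounds.

Measured so far in an assay on isolated protein for binding affinity to metabotropic glutamate receptor 5 (Homo sapiens); on this read-out higher numbers stand for weaker inhibition and lower numbers for stronger inhibition:
compound 1, `O=C1COc2cccc(C(=O)Nc3cccc(Cl)c3)c2N1`, 2900 nM
compound 2, `O=C(Nc1cccc(Cl)c1)c1cccc2cc[nH]c12`, 3900 nM
compound 3, `O=C(Nc1ccccc1)c1cccc2oc(=O)[nH]c12`, 2200 nM

Compound 3 shows the lowest of the three numbers in this assay, yet its gaps to compound 1 and to compound 2 both lie within the usual scatter, so the three compounds cannot be told apart on these data. Among the measured compounds shown here, no pair among them differs in just one place, so no single step between measured compounds is known.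

Compound 4, `COc1cccc(NC(=O)c2cccc3oc(=O)[nH]c23)c1`, differs from compound 3 in one place: methoxy in place of hydrogen on an aromatic carbon. The change sits on an aromatic carbon of a six-membered aromatic ring of carbon only, meta to a large group.

Nothing measured here tells how such a change plays out in this assay. The writer therefore expects no step beyond the scatter, in either direction. For compound 4 the estimated value in this assay is 1800 nM, with a range from 600 nM to 5500 nM, which corresponds to an expected step of a 1.2-fold lower number from compound 3 to compound 4 (0.09 log units; within the scatter).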

Compound 4, inhibition constant: 3900 nM
Compound 4: middle estimate off by 2.2-fold (0.34 log units), on the low side; measured number inside the range.
By their numbers in this assay, from the lowest: compounds 3, 1, 2 and 4 (each within the scatter of the next).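

In this assay, among the compounds shown here, the only step known between two compounds that differ in one place is a 1.8-fold higher number from compound 3 to compound 4 (0.25 log units; within the scatter) and it lies within the scatter. For the compounds shown here, on these two compounds, the aromatic carbon of the six-membered aromatic ring of carbon only, meta to a large group, thus carries methoxy in place of hydrogen with no step that can be told from the scatter. No measurement at hand bears on why this is so.

As far as these compounds go, it remains open whether an amine, a carboxylic acid or a longer chain such as ethoxy at this same place would give a step beyond the scatter. From the compounds shown here alone, it is also open whether methoxy would give a similarly small step on other aromatic carbons of this ring or on the cores of compound 1 and compound 2.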